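This account rests on a few compounds, and the source may have more. Where it says the series, first, only, none or still open, it means among the compounds named here.

The measured compounds:
compound 1 `COc1cc(-c2nnc(SCC(=O)Nc3ccc(/C(C)=N/O)cc3)n2-c2ccccc2)cc(OC)c1OC` gives 59% in a functional assay on the whole organism (strain albino) for inhibition, with Rattus norvegicus as the target, read by paw edema, with stated times of 30 min and 1 h, at a dose of 0.28 mmol/kg by the oral route; on this read-out lower numbers stand for less inhibition and higher numbers for more inhibition at the one dose given (going by the name of the read-out);
compound 2 `C/C(=N\O)c1ccc(NC(=O)CSc2nnc(-c3ccccc3)n2-c2ccccc2)cc1` gives 50% in this assay;
compound 3 `CCn1c(SCC(=O)Nc2ccc(/C(C)=N/O)cc2)nnc1-c1cc(OC)c(OC)c(OC)c1` gives 29% in this assay.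

Compound 1 has the highest of the three numbers, but only one gap is clear: a number 9 percentage points lower from compound 1 to compound 2 (within the scatter), whereas a number 30 percentage points lower from compound 1 to compound 3 (beyond the scatter). So compound 1 and compound 2 cannot be ordered, and compound 3 alone sits apart.

Compound 4 `COc1cc(-c2nnc(SCC(=O)Nc3ccc(C(C)=O)cc3)n2-c2ccccc2)cc(OC)c1OC` is not yet measured. It differs from compound 1 in one place: a group of 3 heavy atoms (2 carbon, 1 oxygen; no ring) in place of a group of 4 heavy atoms (2 carbon, 1 nitrogen, 1 oxygen; no ring), on an aromatic carbon. Neither measured step touches this place. The step from compound 1 to compound 2 swaps the aromatic group on the shared core, and the step from compound 1 to compound 3 swaps the group on the aromatic nitrogen; in both, the group on the six-membered aromatic ring of carbon only stays the same. Going by the values given here, no measured step therefore bears directly on the change to compound 4, and the data give no direction for it. The expectation is a step of no clear direction, most likely within the scatter. Compound 4 is estimated at 50%, with a range from 30% to 70%. This corresponds to an expected step of a number 9 percentage points lower from compound 1 to compound 4 (within the scatter).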

Compound 4, a percentage reported as inhibition, in the whole organism at one dose (the size of the read-out at that dose, not a potency): 49%
Compound 4: the middle estimate sits 1 percentage points above what was measured; measured number inside the range.
By their numbers in this assay, from the lowest: compound 3; then compounds 4, 2 and 1 (each within the scatter of the next).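

In this assay, the exchange of the group of 4 heavy atoms for acetyl, on an aromatic carbon para to a large group, gives a number 10 percentage points lower from compound 1 to compound 4 (within the scatter) and is the first view of this position among the compounds shown. With the rest of compound 1 kept in place, going from 1 hydrogen-bond donor and 2 hydrogen-bond acceptors to 0 hydrogen-bond donors and 1 hydrogen-bond acceptor therefore leaves the number within the scatter at this one dose, so the hydrogen-bond donor of the group that leaves is not required for a reading of this size on this core. No supporting measurement bears on this result, so it stands as an observation without an explanation.

As far as these compounds go, it stays open whether acetyl would behave the same way with the phenyl group of compound 2 or the ethyl group of compound 3 in place. From the compounds shown here alone, it also stays open how this position would respond to a group of a different kind, such as an amine, a carboxylic acid or a longer chain.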